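This account rests on a few compounds, and the source may have more. Where it says the series, first, only, none or still open, it means among the compounds named here.

Of the compounds shown here, three have so far been measured in a functional assay on HeLa cells (Homo sapiens) for antiproliferative activity, read by MTT assay, with a stated time of 72 h; a higher number here means a weaker inhibitor, a lower number a stronger inhibitor. Compound 1 `CC(C)(C)c1cn(C[C@H](O)[C@H]2OC(=O)C(OCc3ccccc3)=C2OCc2ccccc2)nn1` gives 18300 nM. Among the measured compounds shown here, compound 3 `O=C1O[C@H]([C@@H](O)Cn2cc(-c3cc(F)cc(F)c3)nn2)C(OCc2ccccc2)=C1OCc1ccccc1` gives 40800 nM, and the step of a 2.2-fold higher number from compound 1 to compound 3 (0.35 log units; beyond the scatter) is the only single change measured to date. Compound 2 `COc1ccc(-c2cn(C/C=C3\OC(=O)C(OCc4ccccc4)=C3OCc3ccccc3)nn2)cc1` returns no number but a limit of the assay, > 100000 nM. Among the three values shown, compound 2 sits at the limit of > 100000 nM in this assay, at which 1 of the 3 values shown sits. Compound 4 `Cc1ccc(-c2cn(C/C=C3\OC(=O)C(OCc4ccccc4)=C3OCc3ccccc3)nn2)cc1` differs from compound 2 in this way: methyl in place of methoxy on an aromatic carbon. No measured step involves a methoxy or a methyl group, so nothing shown speaks directly to this change, and the one measured step of a 2.2-fold higher number from compound 1 to compound 3 (0.35 log units; beyond the scatter) concerns another part of the molecule. Compound 4 is therefore expected to remain near the limit, with an estimated step of a number no higher from compound 2 to compound 4 (the limit leaves the size open). The estimate for compound 4 is 100000 nM, between 40000 nM and 250000 nM.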

Compound 4, half-maximal inhibitory concentration: 7480 nM
Estimate against measurement, compound 4: 13-fold (1.13 log units) above, outside the stated range (below it).
By their numbers in this assay, from the lowest: compound 4; then compound 1; then compound 3. At a limit, above all of these: compound 2.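

With an at least 13-fold lower number from compound 2 to compound 4 (1.12 log units; beyond the scatter) in this assay, the group para to a large group on the six-membered aromatic ring proves able to move the result far more than the earlier 2.2-fold higher number from compound 1 to compound 3 (0.35 log units; beyond the scatter). Compound 2 stands at a limit of the assay, not at a number: the limit of > 100000 nM in this assay, at which 1 of the 4 values shown sits.

Methyl is the only replacement for methoxy shown at this place, so it remains open whether an ethyl group, a chlorine atom or an amine would behave in the same way. It is also open whether methyl would have the same effect with the other linkers shown.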